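A few compounds are considered here, and "the series" means these few. Any claim that something is new, unique, unknown or untested is made for them only; others in the source may bear on it.

Measured so far in a functional assay on MDA-MB-231 cells (Homo sapiens) for cytotoxicity, read by MTT assay, with a stated time of 96 h; on this read-out lower numbers stand for stronger inhibition and higher numbers for weaker inhibition:
- compound 1 `CC[C@H](NC)C(=O)N[C@@H]1C(=O)N2[C@@H](CC[C@@H]1CN)CC[C@H]2C(=O)NC(c1ccccc1)c1ccccc1`: 542 nM
- compound 2 `CC[C@H](N)C(=O)N[C@@H]1C(=O)N2[C@@H](CC[C@@H]1CCN)CC[C@H]2C(=O)NC(c1ccccc1)c1ccccc1`: 12900 nM

Compound 2, at 12900 nM, holds the higher of the two numbers, and compound 1, at 542 nM, lies lower by more than the scatter. Among the measured compounds shown here, these two compounds differ in more than one place, so no single-change step has been measured.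

Compound 3 `CC[C@H](NC)C(=O)N[C@@H]1C(=O)N2[C@@H](CC[C@@H]1CCN)CC[C@H]2C(=O)NC(c1ccccc1)c1ccccc1` follows from compound 2 by methyl in place of hydrogen on an amine nitrogen. A downward step beyond the scatter is expected in this assay. This expectation rests only on compound 1, which carries the methylamino group and gives 542 nM. The step expected is an 8.6-fold lower number from compound 2 to compound 3 (0.93 log units; beyond the scatter). Compound 3 is estimated at 1500 nM, with an expected range of 350 nM to 6500 nM.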

Compound 3, half-maximal inhibitory concentration: 2300 nM
Beside the measured number, compound 3's estimate is 1.5-fold (0.19 log units) below it, and the stated range covers the measured number.
By their numbers in this assay, from the lowest: compound 1; then compound 3; then compound 2.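

In this assay the methyl on the amine nitrogen now has a step of its own, a 5.6-fold lower number from compound 2 to compound 3 (0.75 log units; beyond the scatter), so amino to methylamino counts beyond the scatter with the rest of the structure held fixed. The other place can also be read alone: aminomethyl in place of amino on a saturated chain carbon bound to a saturated ring carbon gives a 4.2-fold higher number from compound 1 to compound 3 (0.63 log units; beyond the scatter), which is also beyond the scatter, so the gap between compound 1 and compound 2 no longer rests on an unresolved pair of changes. No measurement at hand accounts for either step.

On these data alone, whether the methyl step holds with the side chain of compound 1 remains open. So does how an ethyl group or a second methyl on that nitrogen would read, or a hydroxyl group in place of the side-chain amine.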